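Ear inhibition series: halophenyl swap on the carbonyl carbon

This account rests on a few compounds, and the source may have more. Where it says the series, first, only, none or still open, it means among the compounds named here.

Three compounds of a shared core have been run in a functional assay on the whole organism (Ear) for inhibition, with Mus musculus as the target, with a stated time of 30 min, at a dose of 100 mg/kg by the intraperitoneal route; on this read-out higher numbers stand for more inhibition at the one dose given (going by the name of the read-out) and lower numbers for less inhibition. Compound 1 `Cc1ccc(C(=O)/C=C/c2ccc(/C=N/NC(=O)c3ccccc3)cc2)c(C)c1` gives 0.18%. Compound 2 `O=C(/C=C/c1ccc(/C=N/NC(=O)c2ccncc2)cc1)c1ccc(Br)cc1` gives 55.7%. Compound 3 `N=C(N)N/N=C/c1ccc(/C=C/C(=O)c2ccc(Cl)cc2)cc1` gives 56.4%, the highest of the three numbers, though its gap to compound 2 lies within the scatter while its gap to compound 1 lies beyond it. Compound 4 `N=C(N)N/N=C/c1ccc(/C=C/C(=O)c2ccccc2F)cc1` has not been measured; it differs from compound 3 by 2-fluorophenyl in place of 4-chlorophenyl on a carbonyl carbon. For the measured compounds named here, no measured pair isolates this change, so no step size is known from the data. The group on the carbonyl carbon remains a halophenyl in both compounds, and a small loss or no change beyond the scatter is expected. Compound 4 is expected to give 45%, within 20% to 65%, an estimated step of a number 11.4 percentage points lower from compound 3 to compound 4 (beyond the scatter).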

Compound 4, a percentage reported as inhibition, in the whole organism at one dose (the size of the read-out at that dose, not a potency): 91.7%
The estimate for compound 4 lay 46.7 percentage points below the measured number, outside the stated range (above it).
By their numbers in this assay, from the lowest: compound 1; then compounds 2 and 3 (each within the scatter of the next); then compound 4.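

In this assay, 2-fluorophenyl in place of 4-chlorophenyl on a carbonyl carbon gives a number 35.3 percentage points higher from compound 3 to compound 4 (beyond the scatter). This position is therefore sensitive to which halophenyl it carries, even though the two groups have the same heavy-atom count and the same kind of ring. Nothing available accounts for the size of this step.

As far as these compounds go, it remains open whether the halogen or its placement on the ring carries the step, and 2-chlorophenyl or 4-fluorophenyl would separate the two. From the compounds shown here alone, whether a methoxyphenyl or unsubstituted phenyl group holds the number also remains open.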